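The source may report more compounds than this note shows. Statements on the series, on what has been measured and on what is new or still open speak of the compounds shown alone.

In a functional assay on SMMC-7721 cells (Homo sapiens) for inhibition, read by CCK-8 assay, with a stated time of 72 h, tested at 8 uM (on this read-out higher numbers stand for more inhibition of growth at the one concentration tested and lower numbers for less inhibition of growth), compound 1 `Nc1ccccc1NC(=O)/C=C/c1ccc(CSc2cccc(F)c2)cc1` gives 8.25%, the lowest of the three numbers at hand. Compound 2 `Cc1ccc(SCc2ccc(C(=O)Nc3ccccc3N)cc2)cc1` gives 82.7% and compound 3 `Nc1ccccc1NC(=O)c1ccc(CSc2ccc(F)cc2)cc1` gives 81.9%. Both lie beyond the scatter from compound 1, but their shared core differs from the core of compound 1, so those gaps do not isolate the change considered here. Compound 4 `CC(C)(C)c1ccc(SCc2ccc(/C=C/C(=O)Nc3ccccc3N)cc2)cc1` keeps the core of compound 1 and alters only the group on the sulfur: 4-(tert-butyl)phenyl in place of 3-fluorophenyl on a sulfur. Within the data shown here, no compound carrying 4-(tert-butyl)phenyl has been measured. Among the measured compounds shown here, the only measured step in a single place is a number 0.8 percentage points lower from compound 2 to compound 3 (within the scatter), which stayed within the scatter, and it belongs to the other core. On that thin guide, no step beyond the scatter is expected in this assay, and the estimated change is a number 5.8 percentage points higher from compound 1 to compound 4 (within the scatter), upward. Compound 4 is therefore expected at 14%, with an estimated range from 3% to 40%.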

Compound 4, percent growth inhibition at one concentration: 23.6%
Compound 4: middle estimate off by 9.6 percentage points, on the low side; measured number inside the range.
By their numbers in this assay, from the lowest: compound 1; then compound 4; then compounds 3 and 2 (each within the scatter of the next).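

In this assay, among these compounds, the group on the sulfur of the core of compound 1 proves able to move the number: a number 15.4 percentage points higher from compound 1 to compound 4 (beyond the scatter), a modest step, whereas the one earlier single-place step, a number 0.8 percentage points lower from compound 2 to compound 3 (within the scatter), belonged to the other core. The entering 4-(tert-butyl)phenyl has 10 heavy atoms against 7 for the leaving 3-fluorophenyl, while both keep one six-membered aromatic ring of carbon only, so this single pair cannot separate the gain of tert-butyl from the loss of fluoro. No measurement at hand offers an explanation for the step.

From the compounds shown here alone, it remains open whether a plain phenyl, or a ring bearing an amine or a carboxylic acid, on that sulfur would give a similar number on this core. Also open, going by these compounds, is whether 4-(tert-butyl)phenyl would shift the number on the core shared by compound 2 and compound 3.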